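Replacing piperidin-1-yl in compound 1 with 1H-imidazol-1-yl

This account rests on a few compounds, and the source may have more. Where it says the series, first, only, none or still open, it means among the compounds named here.

The series is followed in an ADME assay on MRC5 cells (Homo sapiens) for cytotoxicity (on this read-out lower numbers stand for stronger inhibition and higher numbers for weaker inhibition), starting from compound 1 (`N#CCN(CCCCN1CCCCC1)C(=O)OCc1ccccc1`). Compound 1 gives > 64000 nM as a limit of the assay, not a number. Compound 2 (`N#CCN(CCCCO)C(=O)OCc1ccccc1`) gives > 64000 nM as a limit too. Compound 3 (`N#CCN(CCCCN1CCN(c2ccc(F)cc2)CC1)C(=O)OCc1ccccc1`) gives > 64000 nM as a limit as well. Compound 1 therefore has no readable position of its own, and the whole set stands at the limit of > 64000 nM in this assay, at which 3 of the 3 values shown sit, without a single number among them.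

Compound 4 (`N#CCN(CCCCn1ccnc1)C(=O)OCc1ccccc1`) carries 1H-imidazol-1-yl in place of piperidin-1-yl on a saturated chain carbon, four bonds along the chain from an amide-type nitrogen. Going by the values given here, the one measured step at this place, hydroxy in place of piperidin-1-yl, is a step that the two limits leave unreadable from compound 1 to compound 2 and offers no size to carry over. Because of the limit of > 64000 nM in this assay, at which 3 of the 3 values shown sit, no step beyond the scatter is expected in this assay and no direction can be given. The expected step is a number no higher from compound 1 to compound 4 (the limit leaves the size open) as a working figure only. Compound 4 is estimated at 64000 nM with an expected range from 32000 nM to 128000 nM and will most likely be reported only as a limit.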

Compound 4, half-maximal inhibitory concentration: > 64000 nM
Compound 4 ended at the assay's limit (the forecaster's own chance of this, stated with the estimate: 85%); the middle value sits exactly at the limit.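

In this assay compound 4 gives > 64000 nM, which is a limit and not a number. The steps from compound 1 and from compound 2 to compound 4 therefore cannot be read. The compounds shown leave open whether any group at this place on the chain changes the read-out, because none gives a number: the limit of > 64000 nM in this assay, at which 4 of the 4 values shown sit.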